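Vinyl sulfone series: hydroxy removal and macrophage cytotoxicity

The source may report more compounds than this note shows. Statements on the series, on what has been measured and on what is new or still open speak of the compounds shown alone.

Measured so far:
compound 1, `O=C(NCc1ccccc1C(=O)N[C@H](/C=C/S(=O)(=O)c1ccccc1)CCc1ccccc1)c1cccc(O)c1`: 36000 nM
compound 2, `O=C(NCc1ccccc1C(=O)N[C@H](/C=C(\F)S(=O)(=O)c1ccccc1)CCc1ccccc1)c1ccccc1`: 43000 nM

Both compounds were read in a toxicity assay on J774.1 cells (Mus musculus) for cytotoxicity, read by MTT assay, with a stated time of 48 h; a lower number here means that less compound is tolerated, a higher number that more compound is tolerated. Compound 1 gives 36000 nM, the lower of the two numbers recorded, and the nearest neighbour is compound 2 at 43000 nM; the gap between them lies within the scatter, so the two values are not distinguished. Among the measured compounds shown here, compound 2 differs from compound 1 in more than one place and no single step is recorded for the pair, so only the two values themselves can be compared.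

The next compound, compound 3, `O=C(NCc1ccccc1C(=O)N[C@H](/C=C/S(=O)(=O)c1ccccc1)CCc1ccccc1)c1ccccc1`, is obtained from compound 1 by one change: hydrogen in place of hydroxy on an aromatic carbon, on an aromatic carbon of a six-membered aromatic ring of carbon only, meta to a large group. For the measured compounds named here, no measured pair isolates this change. Compound 2, which also carries a plain phenyl at this position, sits within the scatter of compound 1, and on that basis no step beyond the scatter is expected in this assay.

Compound 3 is therefore expected to give 40000 nM, within 20000 nM to 80000 nM, which means an estimated step of a 1.1-fold higher number from compound 1 to compound 3 (0.05 log units; within the scatter).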

Compound 3, half-maximal cytotoxic concentration: > 100000 nM
Compound 3: only a limit was reported; the forecaster's own chance of this, stated with the estimate: 15%; middle value at least 2.5-fold (0.39 log units) away from the limit.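

In this assay compound 3 gives > 100000 nM, which is a limit of the assay and not a number: the limit of > 100000 nM in this assay, at which 1 of the 3 values shown sits. Among the compounds shown here, the comparison of compound 1 with compound 3 is the first that isolates this position, and the change from 3-hydroxyphenyl to phenyl gives an at least 2.7-fold higher number from compound 1 to compound 3 (0.44 log units; beyond the scatter), so the hydroxy is not neutral for tolerance in these cells, a point the earlier values could not settle. With the benzamido held constant, the change at the other end of the molecule gives an at least 2.3-fold higher number from compound 2 to compound 3 (0.36 log units; beyond the scatter), so 2-fluoro-2-(phenylsulfonyl)ethenyl and 2-(phenylsulfonyl)ethenyl are also distinguished in this readout, and the phenyl alone does not fix the outcome.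

As far as these compounds go, both steps are bounded on one side only, so their true sizes and their relative sizes remain open. Also open, from the compounds shown here alone, is whether a methoxy, an amine or a carboxylic acid in place of the hydroxy would keep the number of compound 1 or move it towards that of compound 3, and whether the hydroxy has a comparable effect in the presence of 2-fluoro-2-(phenylsulfonyl)ethenyl.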